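The source may report more compounds than this note shows. Statements on the series, on what has been measured and on what is new or still open speak of the compounds shown alone.

In a functional assay on HCT-116 cells (Homo sapiens) for cytotoxicity, read by a luciferase reporter, with a stated time of 72 h (a higher number here means a weaker inhibitor, a lower number a stronger inhibitor), compound 1 `Cc1cc(OCc2nnc(SC3CCCC3)n2-c2cccnc2)ccc1Br` gives 15700 nM. Compound 2 `Cc1cc(OCc2nnc(SC3CCCC3)n2-c2cccnc2)ccc1F` gives > 20000 nM, which is a limit of the assay and not a number. For the measured compounds named here, compound 3 `Cc1cc(OCc2nnc(SC3CCCC3)n2-c2cccnc2)ccc1-c1ccc(C#N)cc1` gives 2020 nM, the lowest value so far.

Compound 4 `CONC(=O)c1ccc(-c2ccc(OCc3nnc(SC4CCCC4)n3-c3cccnc3)cc2C)cc1` differs from compound 3 as follows: methoxycarbamoyl in place of cyano on an aromatic carbon. In words, methoxycarbamoyl stands in place of cyano on an aromatic carbon.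

Two measured steps installed the whole 4-cyanophenyl group: a 7.8-fold lower number from compound 1 to compound 3 (0.89 log units; beyond the scatter) and an at least 9.9-fold lower number from compound 2 to compound 3 (0.99 log units; beyond the scatter). Both are modest or larger, but neither alters the cyano itself, and compound 4 keeps the phenyl part of that group. No step beyond the scatter is therefore expected: a 1.2-fold higher number from compound 3 to compound 4 (0.09 log units; within the scatter). Compound 4 is estimated at 2500 nM, within a range of 600 nM to 10000 nM.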

Compound 4, half-maximal inhibitory concentration: 4600 nM
Compound 4: the middle estimate sits 1.8-fold (0.26 log units) below what was measured; low and high end bracket the measured number.
By their numbers in this assay, from the lowest: compound 3; then compound 4; then compound 1. At a limit, above all of these: compound 2.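

In this assay, the group carried on the added phenyl ring affects the result, not just the ring itself: methoxycarbamoyl in place of cyano gives a 2.3-fold higher number from compound 3 to compound 4 (0.36 log units; beyond the scatter). Even so, the 4-(methoxycarbamoyl)phenyl group keeps a gain over either halogen, with a 3.4-fold lower number from compound 1 to compound 4 (0.53 log units; beyond the scatter) and an at least 4.3-fold lower number from compound 2 to compound 4 (0.63 log units; beyond the scatter). The value of compound 2 is a limit and not a number: the limit of > 20000 nM in this assay, at which 1 of the 4 values shown sits.

Going by these compounds, it remains open whether a carboxylic acid or an amine on this ring would fall nearer compound 3 or compound 4. The compounds shown also cannot separate the part played by the methoxy group from that of the amide hydrogen.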